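The source may report more compounds than this note shows. Statements on the series, on what has been measured and on what is new or still open speak of the compounds shown alone.

Compound 3, with the structure `C#CCNC1CCc2c(SCCc3ccc(C(F)(F)F)cc3)cccc21`, gives 8780 nM in an ADME assay on isolated protein for inhibition of Amine oxidase [flavin-containing] B (Homo sapiens); a lower number here means a stronger inhibitor, a higher number a weaker inhibitor. Among the compounds for which a number rather than a limit is known in this assay, compound 3 sits at the lowest value: compound 1, with the structure `C#CCNC1CCc2c(SCc3ccc4ccccc4c3)cccc21`, gives 69300 nM in this assay, a higher value than that of compound 3, and the gap between the two lies beyond the usual scatter of repeated measurements. Compound 2, with the structure `C#CCNC1CCc2c(SCc3cccc(C)c3)cccc21`, gives > 100000 nM in this assay, which is a limit of the assay and not a number; it sits at the limit of > 100000 nM in this assay, at which 1 of the 3 values shown sits.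

Compound 4, with the structure `C#CCNC1CCc2c(SCCc3ccc(Cl)cc3)cccc21`, has not yet been measured in this assay. Its structure differs from compound 3 in one place: chloro in place of trifluoromethyl on an aromatic carbon.

Going by the values given here, no step between measured compounds matches this change, so no size for it can be read from the data. The shared core of compound 3 and compound 4 is kept, as is the two-carbon chain between the sulfur and the substituted ring. The substituent on the ring is exchanged for a smaller one of the same kind of position. Compound 4 is expected to lie close to compound 3, the step of a 1.0-fold higher number from compound 3 to compound 4 (0.01 log units; within the scatter) being within or only slightly beyond the scatter. Compound 4 is therefore estimated to give about 9000 nM in this assay, with a likely range from 3000 nM to 30000 nM.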

Compound 4, half-maximal inhibitory concentration: 920 nM
Compound 4: the middle estimate sits 9.8-fold (0.99 log units) above what was measured; measured number outside the range, below it.
By their numbers in this assay, from the lowest: compound 4; then compound 3; then compound 1. At a limit, above all of these: compound 2.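

Going by these compounds alone, the exchange of trifluoromethyl for chloro, on an aromatic carbon para to a large group, gives in this assay a 9.5-fold lower number from compound 3 to compound 4 (0.98 log units; beyond the scatter), and this is the first step that isolates a single place. It shows that this position is not indifferent to what it carries: the number moves beyond the scatter, although the change involves 4 heavy atoms leaving and 1 entering, with no hydrogen-bond donor or acceptor and no net charge on either side. The one limit shown, for a compound that differs from these two in more than one place, has no bearing on this step, and nothing measured here explains its size.

Going by these compounds, how fluoro, bromo, methoxy, a nitrile or a plain hydrogen at this same position would compare with chloro remains open, so a single step cannot yet show a trend across substituents. Also open, on these data alone, is whether chloro would give a similar result with a longer chain between the sulfur and the substituted ring.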